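Thiazolyl for phenyl on the piperazine of an oxime ether

The compounds below may be only part of what the source reports. "The series", "measured", "known", "first", "only" and "open" are said of these compounds alone.

Measured compounds:
compound 1, `Cc1ccccc1/C(CCN1CCN(c2ccccn2)CC1)=N\O`: 72%
compound 2, `O/N=C(/CCN1CCN(c2ncccn2)CC1)c1ccccc1`: 52%
compound 3, `CCO/N=C(\CCN1CCN(c2ccccc2)CC1)c1ccccc1`: 80%

In a functional assay on HEK293 cells with D(4) dopamine receptor (Homo sapiens) as the target, read by FLIPR (on this read-out higher numbers stand for larger maximal responses and lower numbers for smaller maximal responses), compound 3 gives 80%, the highest of the three numbers. Compound 1, at 72%, lies within the usual scatter of compound 3, so the two cannot be told apart on this read-out. Compound 2, at 52%, lies beyond the scatter and clearly below compound 3. Going by the values given here, compounds 1 and 2 each differ from compound 3 in more than one place, so no single step between measured compounds is known here.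

Compound 4, `CCO/N=C(\CCN1CCN(c2nccs2)CC1)c1ccccc1`, differs from compound 3 in one place: 1,3-thiazol-2-yl in place of phenyl on an amine nitrogen in a ring. The amine nitrogen in the ring now bears a five-membered aromatic ring with two hetero atoms instead of a six-membered aromatic ring of carbon only.

Among the compounds with values here, with no comparable step among the measured compounds, the account can only offer an expectation. Compound 4 is estimated to give 68% in this assay, with a range from 50% to 85%. The expected step of a number 12 percentage points lower from compound 3 to compound 4 (beyond the scatter) is a small decrease that may well stay within the scatter.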

Compound 4, largest response reached (reported as efficacy), in percent of the reference or control that the assay uses: 72%
Beside the measured number, compound 4's estimate is 4 percentage points below it, within the range that was stated.
By their numbers in this assay, from the lowest: compound 2; then compounds 1, 4 and 3 (each within the scatter of the next).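

In this assay, going by these compounds alone, the change from phenyl to 1,3-thiazol-2-yl on an amine nitrogen in a ring gives a number 8 percentage points lower from compound 3 to compound 4 (within the scatter), the first single change in this set that can be read directly. At this position, a five-membered aromatic ring with two hetero atoms, counted with 2 hydrogen-bond acceptors, can therefore take the place of a six-membered aromatic ring of carbon only, counted with 0, without a difference in maximal response that can be told apart on this read-out. No measurement on hand accounts for this result, and the outcome rests on this one pair of compounds.

The compounds shown leave open whether a non-aromatic group on the same amine nitrogen, such as a benzyl or a simple methyl, would keep a maximal response in the same range in this assay. They also leave open whether the step from phenyl to 1,3-thiazol-2-yl would read the same way on a compound carrying a hydroxyl or a longer chain in place of the ethyl ether of compound 3.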